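The source may report more compounds than this note shows. Statements on the series, on what has been measured and on what is new or still open speak of the compounds shown alone.

Measured so far in an assay on isolated protein for inhibition of histone acetyltransferase p300 (Homo sapiens), with a stated time of 60 min; on this read-out higher numbers stand for weaker inhibition and lower numbers for stronger inhibition:
- compound 1 `O=C(Nc1ccc2[nH]nnc2c1)[C@H]1CCCN1C(=O)C1(c2cccc(Cl)c2)CCCC1`: 20 nM
- compound 2 `COc1ccc(NC(=O)[C@H]2CCCN2C(=O)C2(c3ccc(Cl)cc3)CCC2)cc1`: 10 nM
- compound 3 `COc1ccc(NC(=O)[C@H]2CCCN2C(=O)C2(c3ccc(Cl)cc3)CCCCC2)cc1`: 20 nM

Compound 1 stands level with compound 3 at the digits reported, and the two share the highest number of the three. Its nearest neighbour on this read-out is compound 3, with no change at the digits reported, and its furthest is compound 2, whose number is lower but still inside the scatter of repeat measurements. All three values therefore sit in one band; no ordering among them can be stated.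

The step considered here goes from compound 1 to compound 4 `O=C(Nc1ccc(O)cc1)[C@H]1CCCN1C(=O)C1(c2cccc(Cl)c2)CCCC1`, which has not been measured. The change is a group of 7 heavy atoms (6 carbon, 1 oxygen; one six-membered aromatic ring of carbon only) in place of a group of 9 heavy atoms (6 carbon, 3 nitrogen; one five-membered aromatic ring with 3 hetero atoms, one six-membered aromatic ring of carbon only), on an amide-type nitrogen. The other parts of the molecule are unchanged.

Among the compounds with values here, no step between measured compounds touches this position, so the expectation rests on the band of the three measured values alone. For compound 4 the step is expected to be a 1.3-fold higher number from compound 1 to compound 4 (0.10 log units; within the scatter), that is, no change beyond the scatter in either direction. Compound 4 is accordingly estimated at 25 nM, with a range from 8 nM to 80 nM.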

Compound 4, half-maximal inhibitory concentration: 0.631 nM
For compound 4 the middle estimate is 40-fold (1.60 log units) above the measured one; the whole stated range lies above it.
By their numbers in this assay, from the lowest: compound 4; then compounds 2, 1 and 3 (each within the scatter of the next).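

In this assay, placing 4-hydroxyphenyl on the amide-type nitrogen, in place of the group holding the five-membered aromatic ring with 3 hetero atoms, gives a 32-fold lower number from compound 1 to compound 4 (1.50 log units; beyond the scatter), so this position can move the read-out well beyond the scatter, which the single band of the three earlier values did not reveal. The two groups have in common a six-membered aromatic ring of carbon only and the same count of hydrogen-bond donors, so the step goes with a swap of the fused five-membered aromatic ring for a hydroxyl group, not with a loss of the carbon-only ring or a change in donor count. Nothing at hand accounts for the size of this step.

From the compounds shown here alone, it remains open which part of the change carries the step, and an unsubstituted phenyl or a 4-aminophenyl group on the same amide-type nitrogen would help separate the contribution of the hydroxyl group from that of the lost five-membered ring. Going by these compounds, it is also open whether 4-hydroxyphenyl would give a similar step on the cores of compound 2 and compound 3.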